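This account rests on a few compounds, and the source may have more. Where it says the series, first, only, none or still open, it means among the compounds named here.

Measured compounds:
Compound 1 `O=c1[nH]cc(S(=O)(=O)Nc2cccc(-c3cn(-c4cccc(F)c4)nn3)c2)c(=O)[nH]1` – > 20000 nM
Compound 2 `O=c1[nH]cc(S(=O)(=O)Nc2cccc(-c3cn(-c4ccc(F)cc4)nn3)c2)c(=O)[nH]1` – > 20000 nM

In a functional assay on OVCAR-3 cells (Homo sapiens) for antiproliferative activity, read by MTT assay, with a stated time of 24 h (on this read-out higher numbers stand for weaker inhibition and lower numbers for stronger inhibition), compound 1 gives > 20000 nM, which is a limit of the assay and not a number. In the same test compound 2 gives > 20000 nM, again a limit rather than a number. The single step among the measured compounds, a step that the two limits leave unreadable from compound 1 to compound 2, is therefore of unreadable size: both ends sit at the limit, as shown by the limit of > 20000 nM in this assay, at which 2 of the 2 values shown sit. Compound 2 thus stands at the limit, with no number of its own to place it against compound 1.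

Compound 3 `O=c1[nH]cc(S(=O)(=O)Nc2cccc(-c3cn(-c4ccccc4Cl)nn3)c2)c(=O)[nH]1` differs from compound 2 in one place: 2-chlorophenyl in place of 4-fluorophenyl on an aromatic nitrogen. Among the measured compounds shown here, no measured step bears a readable size on this change, and the one step that exists, from compound 1 to compound 2, only shows two limits. The expectation for compound 3 is therefore that it also ends at or near the limit, with an estimated step that the limit leaves unreadable from compound 2 to compound 3. Compound 3 is estimated at 30000 nM, within the range 10000 nM to 100000 nM.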

Compound 3, half-maximal inhibitory concentration: 5370 nM
Compound 3: middle estimate off by 5.6-fold (0.75 log units), on the high side; the whole stated range lies above it.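

In this assay the 2-chlorophenyl group on the aromatic nitrogen gives an at least 3.7-fold lower number from compound 2 to compound 3 (0.57 log units; beyond the scatter) when it replaces 4-fluorophenyl and an at least 3.7-fold lower number from compound 1 to compound 3 (0.57 log units; beyond the scatter) when it replaces 3-fluorophenyl. The group on this nitrogen can therefore bring a compound of this series to a readable number, something the two fluorophenyl compounds could not show, since neither gave a number of its own. Both steps are minimum sizes only because the values for compound 1 and compound 2 are limits and not numbers: the limit of > 20000 nM in this assay, at which 2 of the 3 values shown sit.

The change from either fluorophenyl group to 2-chlorophenyl swaps fluorine for chlorine and also alters the place of the halogen on the phenyl ring, so the compounds shown cannot say which of the two matters, and 2-fluorophenyl or 4-chlorophenyl would be needed to pull them apart. Going by these compounds, it also remains open how this position responds to groups of another kind, such as a 2-methoxyphenyl, a 2-aminophenyl or a benzyl group in place of the halogen-bearing phenyl.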